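The source may hold more compounds than are shown below. What is called first, only, known or untested is meant among the compounds shown, and "the series" means these compounds.

Measured in a physicochemical assay for pharmacokinetics; a lower number here means that the compound disappears faster, a higher number that the compound lasts longer:
- compound 1 `O=C(c1ccccc1)N1C(=O)c2ccccc2S1(=O)=O`: > 0.875 h (a limit)
- compound 2 `O=C(NCC1CCCCC1)N1C(=O)c2ccccc2S1(=O)=O`: > 166 h (a limit)

Compound 2 stands only at a limit, > 166 h, and has no exact number. Compound 1 is also known only as a limit. Compound 3 `O=C(NCc1cccs1)N1C(=O)c2ccccc2S1(=O)=O` has thiophen-2-yl in place of cyclohexyl on a saturated chain carbon bound to an amide-type nitrogen. Among the measured compounds shown here, with no measured step to go on, the expected change in this assay is a step that the limit leaves unreadable from compound 2 to compound 3, in neither direction beyond the usual scatter. For compound 3 the estimated half-life is 170 h, with an expected range of 60 h to 500 h.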

Compound 3, half-life: > 166 h
Compound 3 was reported as a limit; the forecaster's own chance of this, stated with the estimate: 50%; the middle value lies beyond the limit too.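

In this assay, among the compounds shown here, compound 3 gives > 166 h, a limit, so no step from compound 1 or compound 2 to compound 3 can be read. The compounds shown leave open whether thiophen-2-yl and cyclohexyl differ at all in half-life.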